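Capping a phenol with cyclopropylmethyl on an aryl-piperazine

This account rests on a few compounds, and the source may have more. Where it says the series, first, only, none or still open, it means among the compounds named here.

Measured compounds:
compound 1 `COc1ccccc1N1CCN(CCCNc2ncccc2C(=O)NC(C)(C)C)CC1` — 10 nM
compound 2 `CN(C)C(=O)c1cccnc1NCCCN1CCN(c2ccccc2O)CC1` — 63.1 nM

In a functional assay on aorta for antagonist activity at Alpha-1D adrenergic receptor (Rattus norvegicus) (on this read-out higher numbers stand for weaker binding and lower numbers for tighter binding), compound 2 gives 63.1 nM and stands highest of the two numbers in hand. Its nearest neighbour, compound 1, gives 10 nM in this assay, a gap beyond the scatter; the two differ in more than one place, so the gap is simply what the two values show. Compound 3 `CN(C)C(=O)c1cccnc1NCCCN1CCN(c2ccccc2OCC2CC2)CC1` is not yet measured. It differs from compound 2 in one place: cyclopropylmethyl in place of hydrogen on an oxygen on an aromatic ring. Going by the values given here, with no single-change step available, the direction rests on the two values alone, and the free hydroxy compound is the weaker of the pair. A modest move toward a lower number is expected, one that could still fall within the scatter, with a 2.1-fold lower number from compound 2 to compound 3 (0.32 log units; beyond the scatter) as the expected step. Compound 3 is therefore estimated at 30 nM in this assay, with a range of 8 nM to 100 nM.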

Compound 3, dissociation constant: 10 nM
For compound 3 the middle estimate is 3.0-fold (0.48 log units) above the measured one, within the range that was stated.
By their numbers in this assay, from the lowest: compounds 1 and 3 (each within the scatter of the next); then compound 2.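

In this assay, replacing the hydrogen on this oxygen with cyclopropylmethyl gives a 6.3-fold lower number from compound 2 to compound 3 (0.80 log units; beyond the scatter), the first single-change step available in this series. The free hydroxy is therefore not required at this oxygen on an aromatic ring for a low number in this assay, and the larger cyclopropylmethoxy is accepted there, though this rests on a single pair of compounds. Nothing in the data explains why the number moves in this direction.

The compounds shown leave open whether the cyclopropyl ring itself matters, or whether a methoxy, an ethoxy or a longer chain on the same oxygen, with the dimethyl amide kept, would give a similar number. From the compounds shown here alone, it is also open whether the same change would give a step of similar size with the amide of compound 1 in place.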